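Chain length and binding: working notes on compound 3

The source may hold more compounds than are shown below. What is called first, only, known or untested is meant among the compounds shown, and "the series" means these compounds.

Measured so far in an assay on isolated protein (Cavia porcellus) with Sigma non-opioid intracellular receptor 1 (Homo sapiens) as the target, read by radioligand binding; on this read-out lower numbers stand for stronger inhibition and higher numbers for weaker inhibition:
compound 1, `CN(C)CCCCOc1ccc2oc(-c3ccccc3)cc(=O)c2c1`, compound 1 gives 400 nM
compound 2, `CN(C)CCCCCCCOc1ccc2oc(-c3ccccc3)cc(=O)c2c1`, compound 2 gives 188 nM

Going by the values given here, compound 2 stands at the lower of the two numbers so far, the other being compound 1, separated by a 2.1-fold lower number from compound 1 to compound 2 (0.33 log units; beyond the scatter). That single step is the only one that bears on the next change, and it is modest in size.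

Compound 3, `CN(C)CCCCCCCCCOc1ccc2oc(-c3ccccc3)cc(=O)c2c1`, is not yet measured. It differs from compound 2 by 2-(dimethylamino)ethyl in place of dimethylamino on a saturated chain carbon, seven bonds along the chain from an oxygen on an aromatic ring. Among the compounds with values here, the change is of the same kind as the one from compound 1 to compound 2, continuing the lengthening of the chain between the aromatic oxygen and the dimethylamino group. Within the data shown here, with only one prior step of this kind, a second lengthening is expected to give at most a small further lowering of the number in this assay, or none beyond the scatter, since nothing shows whether the gain continues or has already flattened.

The step from compound 2 to compound 3 is therefore expected to be a 1.4-fold lower number from compound 2 to compound 3 (0.16 log units; within the scatter). Compound 3 is estimated at 130 nM, with a range from 60 nM to 300 nM.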

Compound 3, half-maximal inhibitory concentration: 202 nM
Estimate against measurement, compound 3: 1.6-fold (0.19 log units) below, and the stated range covers the measured number.
By their numbers in this assay, from the lowest: compounds 2, 3 and 1 (each within the scatter of the next, the first and the last beyond it).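

In this assay, 2-(dimethylamino)ethyl in place of dimethylamino, seven bonds along the chain from an oxygen on an aromatic ring, gives a 1.1-fold higher number from compound 2 to compound 3 (0.03 log units; within the scatter) and so adds no gain beyond the scatter to the one seen on the earlier lengthening; the response to chain length at this position is therefore not a steady one across the three compounds. Over the whole span, 5-(dimethylamino)pentyl in place of dimethylamino, four bonds along the chain from an oxygen on an aromatic ring, gives a 2.0-fold lower number from compound 1 to compound 3 (0.30 log units; within the scatter) and thus stays inside the scatter, whereas the step to compound 2 alone lies beyond it. Nothing on hand accounts for this flat stretch in the series.

The compounds shown leave open whether a still longer chain would hold this level or move away from it, and how chains of intermediate length would sit among these three. They also leave open whether a piperidine or a morpholine in place of dimethylamino would read differently at any of these chain lengths.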